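A few compounds are considered here, and "the series" means these few. Any claim that something is new, unique, unknown or untested is made for them only; others in the source may bear on it.

Measured compounds:
Compound 1 `COc1cccc(C(=O)Nc2cccc(-c3oc4cc(-c5ccc(F)cc5)ccc4c(=O)c3O)c2)c1`: 18900 nM
Compound 2 `CCc1ccc(C(=O)Nc2cccc(-c3oc4cc(-c5ccc(F)cc5)ccc4c(=O)c3O)c2)cc1`: 13200 nM

In a functional assay on HCC1937 cells (Homo sapiens) for antiproliferative activity, read by CCK-8 assay, with a stated time of 72 h (on this read-out higher numbers stand for weaker inhibition and lower numbers for stronger inhibition), compound 2 gives 13200 nM, and compound 1 gives 18900 nM; the two numbers differ only within the scatter, as the step of a 1.4-fold lower number from compound 1 to compound 2 (0.16 log units; within the scatter) shows, so neither compound can be called the stronger of the two.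

Compound 3 `O=C(Nc1cccc(-c2oc3cc(-c4ccc(F)cc4)ccc3c(=O)c2O)c1)c1ccc(-c2ccccc2)cc1` has not yet been measured. It differs from compound 2 by phenyl in place of ethyl on an aromatic carbon.

Within the data shown here, only one measured step bears on this change, the one from compound 1 to compound 2, which also swapped the group attached to the carbonyl carbon and stayed within the scatter. With so little to go on, no step beyond the scatter is expected in either direction for compound 3, and the estimated step is a 1.0-fold lower number from compound 2 to compound 3 (0.01 log units; within the scatter). Compound 3 is therefore expected to give about 13000 nM in this assay, within a range from 4500 nM to 38000 nM.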

Compound 3, half-maximal inhibitory concentration: 44100 nM
Compound 3: middle estimate off by 3.4-fold (0.53 log units), on the low side, and the stated range ends below it.
By their numbers in this assay, from the lowest: compounds 2 and 1 (each within the scatter of the next); then compound 3.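

In this assay, among these compounds, replacing the ethyl of the 4-ethylphenyl group with a phenyl gives a 3.3-fold higher number from compound 2 to compound 3 (0.52 log units; beyond the scatter) and is the first change here to reach beyond the scatter. The 4-phenylphenyl group also separates from the 3-methoxyphenyl group, with a 2.3-fold higher number from compound 1 to compound 3 (0.37 log units; beyond the scatter) as the step, so the group on this carbonyl carbon can affect the read-out, and here the added phenyl goes with weaker inhibition. No measurement at hand gives a reason for this loss.

As far as these compounds go, it remains open whether the loss follows from the ring itself or from the number of atoms added, which a cyclohexyl or a butyl in the same place could help separate. From the compounds shown here alone, it is also open whether a smaller methyl, an amine or a carboxylic acid there would give stronger inhibition than the ethyl.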